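The compounds below may be only part of what the source reports. "The series", "measured", "known", "first", "only" and "open" are said of these compounds alone.

Compound 2 `CCN(CC)CN1C(=O)C(=O)c2c(Br)cccc21` and compound 1 `CN(C)CN1C(=O)C(=O)c2c(Br)cccc21` share a core, and in an ADME assay on MCF-10A cells (Homo sapiens) for cytotoxicity, read by sulforhodamine B assay, with a stated time of 48 h (a lower number here means a stronger inhibitor of growth, a higher number a weaker inhibitor of growth), compound 2 gives 113000 nM while compound 1 gives 67800 nM. The step of a 1.7-fold lower number from compound 2 to compound 1 (0.22 log units; within the scatter) is dimethylamino in place of diethylamino on a saturated chain carbon bound to an amide-type nitrogen in a ring. Compound 3 `CCN(CC)CN1C(=O)/C(=N\c2nc3ccc(C)cc3s2)c2c(Cl)cccc21` carries a different core; how the cores of compound 3 and compound 2 differ is not broken down here. In this assay compound 3 gives 43900 nM. Compound 4 `Cc1ccc2nc(/N=C3\C(=O)N(CN(C)C)c4cccc(Cl)c43)sc2c1` is related to compound 3 by dimethylamino in place of diethylamino on a saturated chain carbon bound to an amide-type nitrogen in a ring, and the place is the same in wording as for the pair already measured, so the change is the same kind. Compound 4 is expected to show a step of a 1.5-fold lower number from compound 3 to compound 4 (0.17 log units; within the scatter), resting on the step of a 1.7-fold lower number from compound 2 to compound 1 (0.22 log units; within the scatter) seen on the other core. Compound 4 is therefore estimated at 30000 nM, with a range from 15000 nM to 65000 nM.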

Compound 4, concentration for 50% growth inhibition: 7020 nM
Compound 4: middle estimate off by 4.3-fold (0.63 log units), on the high side; the measured number lies below the stated range.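

Dimethylamino in place of diethylamino on a saturated chain carbon bound to an amide-type nitrogen in a ring gives a 6.3-fold lower number from compound 3 to compound 4 (0.80 log units; beyond the scatter) in this assay. The size of the step did not carry over from one core to the other: the same change on two cores in this assay, a 1.7-fold lower number (0.22 log units; within the scatter) from compound 2 to compound 1 and a 6.3-fold lower number (0.80 log units; beyond the scatter) from compound 3 to compound 4, 3.8-fold (0.57 log units) apart, beyond the scatter of two such steps. This shows that, in these compounds, the step measured on one core was a poor guide to the step on the other, but with one pair on each core it does not show which feature of the cores sets the gap or what a third core would give.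

The compounds shown leave open whether a pyrrolidine or a morpholine in place of these two amines would follow either step. They also leave open how a longer chain carrying the amine would read in this assay.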